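Removing a Butyl Group from Compound 3

The source may hold more compounds than are shown below. What is called first, only, known or untested is meant among the compounds shown, and "the series" means these compounds.

Of the compounds shown here, three have been measured in a functional assay (Homo sapiens) for inhibition; on this read-out lower numbers stand for stronger inhibition and higher numbers for weaker inhibition. Compound 1 (`COc1cc(/C=C/C(=O)c2ccccc2F)cc(OC)c1`) gives 6000 nM, compound 2 (`COc1cc(/C=C/C(=O)c2ccc(C3CCCCC3)cc2)cc(OC)c1`) gives 39000 nM, and compound 3 (`CCCCOc1ccccc1/C=C/C(=O)c1ccc(OC)c(OC)c1OC`) gives 52000 nM. Compound 3 cannot be told apart from compound 2, since their numbers lie within the scatter of each other. The number for compound 3 lies beyond the scatter above that of compound 1, so it stands at the weaker side of this small set, together with compound 2.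

The next compound, compound 4 (`COc1ccc(C(=O)/C=C/c2ccccc2O)c(OC)c1OC`), differs from compound 3 in one place: hydrogen in place of butyl on an oxygen on an aromatic ring. This is hydrogen in place of butyl on an oxygen on an aromatic ring, or butoxy to hydroxy. Among the compounds with values here, no measured pair differs in only one place, so the data offer no direct precedent for this change. Compound 1 at 6000 nM shows only that clearly lower numbers occur among these compounds.

A modest move towards stronger inhibition therefore seems the likeliest outcome, though a result within the scatter would not surprise. The expected size of this move is an estimated 2.4-fold lower number from compound 3 to compound 4 (0.37 log units; beyond the scatter). For compound 4 the expected value is 22000 nM, with an estimated range from 7000 nM to 70000 nM.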

Compound 4, half-maximal inhibitory concentration: 9000 nM
Compound 4: middle estimate off by 2.4-fold (0.39 log units), on the high side; the measured number falls inside the stated range.
By their numbers in this assay, from the lowest: compounds 1 and 4 (each within the scatter of the next); then compounds 2 and 3 (each within the scatter of the next).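

Within the data shown here, the step from butoxy to hydroxy is the first change in this set that can be read in one place, and in this assay it gives a 5.8-fold lower number from compound 3 to compound 4 (0.76 log units; beyond the scatter). It shows that the butyl on this oxygen on an aromatic ring is not required for inhibition in this series, as the compound carrying hydrogen there gives the stronger inhibition, by a margin beyond the scatter. Nothing measured here bears on why the number drops with this change.

The compounds shown do not separate the effect of losing the butyl chain from the effect of gaining the free hydroxy, and an ethoxy on the same oxygen, or an amine in place of the hydroxy, would be needed to tell how far each counts. From the compounds shown here alone, whether the same exchange would move the number in the same direction on another core, such as the core of compound 1, also stays open, as this is a single step at a single position.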